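A few compounds are considered here, and "the series" means these few. Any claim that something is new, unique, unknown or untested is made for them only; others in the source may bear on it.

Compound 1, with the structure `CC[C@H]1c2cc(Cl)ccc2C(=O)N1c1cncc2c1CCC[C@H]2NC(C)=O`, was tested in an ADME assay on microsomes from liver (Homo sapiens) for metabolic stability, read by LC-MS, using NADPH, with stated times of 10 min and 30 min; a higher number here means faster removal of the compound, a lower number slower removal. In this assay compound 1 gives < 3.5 mL/min/kg, which is a limit of the assay rather than a measured number. Compound 2, `CCC(=O)N[C@@H]1CCCc2c1cncc2N1C(=O)c2ccc(Cl)cc2[C@@H]1CC`, differs from compound 1 only in having a methyl in place of hydrogen on a saturated chain carbon bound to a carbonyl carbon. In this assay compound 2 gives < 3.5 mL/min/kg, again a limit. The step from compound 1 to compound 2 is therefore a step that the two limits leave unreadable from compound 1 to compound 2, and its size cannot be read. A third compound, compound 3 with the structure `CC1(C)c2cc(Cl)ccc2C(=O)N1c1cccnc1`, shares the core. In this assay compound 3 gives < 3.5 mL/min/kg, also a limit. What ties these three results together is the limit of < 3.5 mL/min/kg in this assay, at which 3 of the 3 values shown sit.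

Compound 4, `CC(=O)N[C@@H]1CCCc2c1cncc2N1Cc2cc(Cl)ccc2C1=O`, is the next compound, not yet measured. Compared with compound 1 the change is hydrogen in place of ethyl on a saturated ring carbon. Going by the values given here, none of the measured steps touches this position: the one available step, from compound 1 to compound 2, alters a different place and is unreadable in any case. Among the compounds with values here, the only guidance is that every measured member of this series sits at the limit. The step from compound 1 to compound 4 is thus expected to be a step that the limit leaves unreadable from compound 1 to compound 4, small in this assay. Compound 4 is estimated at 3 mL/min/kg, with a range from 1 mL/min/kg to 8 mL/min/kg.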

Compound 4, clearance: < 3.5 mL/min/kg
Compound 4: a limit, no number; the forecaster's own chance of this, stated with the estimate: 65%; the middle value lies beyond the limit too.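

In this assay compound 4 gives < 3.5 mL/min/kg, which is again a limit and not a number, so the step between compound 1 and compound 4 cannot be read. The compounds shown leave open how fast each is actually removed and whether hydrogen in place of ethyl changes that, because all the results share one value: the limit of < 3.5 mL/min/kg in this assay, at which 4 of the 4 values shown sit.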